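Swapping tert-butyl for ethyl on an ester whose inhibition number sits near zero

The compounds below may be only part of what the source reports. "The series", "measured", "known", "first", "only" and "open" are said of these compounds alone.

Two close relatives have been measured in an ADME assay on HEK293 cells (Homo sapiens) for inhibition, read by CellTiter-Glo, with a stated time of 96 h, tested at 100 uM; on this read-out higher numbers stand for more inhibition at the one concentration tested (going by the name of the read-out) and lower numbers for less inhibition. Compound 1 `CCOC(=O)/C=C/NC(=O)[C@H](O)C(C)(C)CO` gives -5% in this assay. Compound 2 `CC(C)(C)OC(=O)/C=C\NC(=O)[C@@H](O)C(C)(C)CO` gives -11%, which is the smaller of the two numbers shown, but the gap to compound 1 lies within the usual scatter, so the two values cannot be told apart. Going by the values given here, both numbers sit near zero, meaning that at the single concentration tested neither compound holds back the cells to any measurable extent.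

Compound 3 `CCOC(=O)/C=C\NC(=O)[C@@H](O)C(C)(C)CO` has not yet been measured. Its difference from compound 2 is confined to the ester end: ethyl in place of tert-butyl on an oxygen next to a carbonyl group. The rest of the molecule stays as it was. Among the compounds with values here, no measured pair differs in just this way, so the only guide is that the two compounds already measured both rest at the floor of the scale. On that basis the step of a number 3 percentage points higher from compound 2 to compound 3 (within the scatter) is expected to stay within the scatter, in no particular direction. Compound 3 is therefore estimated at -8%, with a likely range from -22% to 6%.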

Compound 3, a percentage reported as inhibition, at one concentration (the size of the read-out at that concentration, not a potency): -6%
Beside the measured number, compound 3's estimate is 2 percentage points below it, within the range that was stated.
By their numbers in this assay, from the lowest: compounds 2, 3 and 1 (each within the scatter of the next).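

In this assay, the place on an oxygen next to a carbonyl group now has its first direct comparison, and ethyl in place of tert-butyl gives no change that can be told from the noise, with a number 5 percentage points higher from compound 2 to compound 3 (within the scatter). This single exchange of a larger group for a smaller one therefore leaves the reading where it was, at least for these two groups. The measured set also gains a comparison of shape as drawn rather than of atoms, with a number 1 percentage points lower from compound 1 to compound 3 (within the scatter), so reversing the stereocentre and the double bond together shows no readable difference either, and the comparison is a clean one in this sense: the fact that compounds 1 and 3 differ only in the configuration as drawn

Going by these compounds, since the stereocentre and the double bond differ together in that pair, the effect of each one alone stays open, and a real effect of one could be hidden by an opposite effect of the other. On these data alone, it also remains unknown whether a carboxylic acid or an amine-bearing chain at the ester end would lift the number away from this flat stretch of values.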